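Carboxy in Place of Nitro on a Shared Core

The compounds below may be only part of what the source reports. "The series", "measured", "known", "first", "only" and "open" are said of these compounds alone.

Compound 1 `Oc1ccc(CNc2cc(C(F)(F)F)cc3[nH]ncc23)cc1` gives 81% in an assay for inhibition of Indoleamine 2,3-dioxygenase 1 (Homo sapiens), with stated times of 10 min and 60 min, tested at 100 uM; a lower number here means a weaker effect, a higher number a stronger effect of the compound at the concentration tested.
Compound 2 `O=[N+]([O-])c1cccc(CNc2cc(C(F)(F)F)cc3[nH]ncc23)c1` gives 69% in this assay.
Compound 3 `FC(F)(F)c1cc(NC[C@H]2CCCCN2)c2cn[nH]c2c1` gives 69% in this assay.

Compound 2 stands level with compound 3 at the digits shown, and together they are the lowest of the three numbers; compound 1 lies higher than both. Among the compounds with values here, the one measured single-point step is a number 12 percentage points lower from compound 1 to compound 3 (beyond the scatter), and it concerns the group on the saturated chain carbon, not a substituent on the six-membered aromatic ring.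

Compound 4 `O=C(O)c1cccc(CNc2cc(C(F)(F)F)cc3[nH]ncc23)c1` differs from compound 2 by carboxy in place of nitro on an aromatic carbon. Within the data shown here, no measured step exchanges one group for another on that aromatic ring, so the step between compound 1 and compound 3 bears on it only indirectly: it shows that changing the group at the chain end moves the read-out modestly, beyond the scatter, without saying in which direction a carboxy rather than a nitro would go. The comparison of compound 1 with compound 2 shows two aromatic groups at the chain end giving numbers that differ by about the size of that step.

With no direct guide, the expected step of a number 1 percentage points lower from compound 2 to compound 4 (within the scatter) for compound 4 is none beyond the scatter. Compound 4 is therefore estimated at 68% in this assay, ranging from 50% to 84%.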

Compound 4, a percentage reported as inhibition, at one concentration (the size of the read-out at that concentration, not a potency): 17%
Beside the measured number, compound 4's estimate is 51 percentage points above it, outside the stated range (below it).
By their numbers in this assay, from the lowest: compound 4; then compounds 2 and 3 (each within the scatter of the next); then compound 1.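

Carboxy in place of nitro on this aromatic carbon, meta to a large group, gives a number 52 percentage points lower from compound 2 to compound 4 (beyond the scatter) in this assay. The earlier compounds shown here showed only a modest change at the chain end, a number 12 percentage points lower from compound 1 to compound 3 (beyond the scatter), whereas this result shows that the read-out can depend strongly on which group sits on the ring, even when the two groups have the same number of heavy atoms. The counted differences are that carboxy has a hydrogen-bond donor and nitro has none, but no measurement here explains the drop.

As far as these compounds go, it remains open whether a methyl ester, an amide or a nitrile in the same place would give a number nearer that of compound 2 or that of compound 4. From the compounds shown here alone, it is also open whether carboxy on another carbon of the ring would give a similar step.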